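This account rests on a few compounds, and the source may have more. Where it says the series, first, only, none or still open, it means among the compounds named here.

Values so far in a functional assay on CCRF-CEM cells (Homo sapiens) (on this read-out higher numbers stand for lower toxicity in this test and lower numbers for higher toxicity in this test), are given below.
- compound 1 (`Cc1cn([C@@H]2O[C@H](CO[Si](C)(C)C(C)(C)C)[C@@]3(OS(=O)(=O)C=C3N)[C@H]2O[Si](C)(C)C(C)(C)C)c(=O)n(CCO)c1=O`) gives 11300 nM
- compound 2 (`Cc1cn([C@@H]2O[C@H](CO[Si](C)(C)C(C)(C)C)[C@@]3(OS(=O)(=O)C=C3N)[C@H]2O[Si](C)(C)C(C)(C)C)c(=O)n(CCCN2C(=O)c3ccccc3C2=O)c1=O`) gives > 250000 nM as a limit of the assay
- compound 3 (`Cc1cn([C@@H]2O[C@H](CO[Si](C)(C)C(C)(C)C)[C@@]3(OS(=O)(=O)C=C3N)[C@H]2O[Si](C)(C)C(C)(C)C)c(=O)n(CCCN(CC(=O)O)CC(=O)O)c1=O`) gives > 250000 nM as a limit of the assay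

Compound 3 stands at > 250000 nM and this is a limit of the assay, not a number. Its position is the limit of > 250000 nM in this assay, at which 2 of the 3 values shown sit, and no exact place can be read for it.

Compound 4 (`Cc1cn([C@@H]2O[C@H](CO[Si](C)(C)C(C)(C)C)[C@@]3(OS(=O)(=O)C=C3N)[C@H]2O[Si](C)(C)C(C)(C)C)c(=O)n(CCCN(C)C)c1=O`) carries dimethylamino in place of bis(carboxymethyl)amino on a saturated chain carbon, three bonds along the chain from an aromatic nitrogen. Within the data shown here, no measured step makes this same exchange, so the evidence is indirect. The two large steps of an at least 22-fold higher number from compound 1 to compound 2 (1.34 log units; beyond the scatter) and an at least 22-fold higher number from compound 1 to compound 3 (1.34 log units; beyond the scatter) both lead from hydroxy to a bigger group and reach the limit. The step that the two limits leave unreadable from compound 2 to compound 3 adds nothing further. Among the measured compounds shown here, compound 1, the only compound with a number, gives 11300 nM and carries the smallest end group of the three.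

Compound 4 also carries a much smaller group than the one that leaves, so a sizeable drop from the limit is expected in this assay, meaning higher toxicity in this test. It may still remain at the limit. The expected move is an at least 6.2-fold lower number from compound 3 to compound 4 (0.79 log units; beyond the scatter) in this read-out. The estimate for compound 4 is 40000 nM within an expected range of 9000 nM to 220000 nM in this read-out.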

Compound 4, half-maximal cytotoxic concentration: 10400 nM
For compound 4 the middle estimate is 3.8-fold (0.59 log units) above the measured one; the range from low to high includes it.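

In this assay, dimethylamino in place of bis(carboxymethyl)amino gives an at least 24-fold lower number from compound 3 to compound 4 (1.38 log units; beyond the scatter), and dimethylamino in place of the ring-bearing end group of compound 2 gives an at least 24-fold lower number from compound 2 to compound 4 (1.38 log units; beyond the scatter). Among the compounds shown, the 3-carbon chain of 3-(dimethylamino)propyl therefore does not by itself hold a compound at the limit, and the exchange at the end of that chain separates compound 4 from compound 2 and compound 3. The earlier contrast also proves not to be tied to hydroxy alone: (dimethylamino)methyl in place of hydroxy gives a 1.1-fold lower number from compound 1 to compound 4 (0.04 log units; within the scatter), so compound 1 and compound 4 cannot be told apart in this read-out.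

Going by these compounds, the values of compound 2 and compound 3 are limits of the assay, so the step between them cannot be read and the true size of both large steps stays unknown: the limit of > 250000 nM in this assay, at which 2 of the 4 values shown sit. Still open is whether a primary amine, a single carboxylic acid on the same chain, or a longer chain carrying dimethylamino would stay level with compound 4 or move towards the limit.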